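A few compounds are considered here, and "the series" means these few. Any claim that something is new, unique, unknown or untested is made for them only; others in the source may bear on it.

Measured so far:
Compound 1 `NC(=O)c1ccc(-c2cccnc2)cc1OC1CCNCC1` gives 1100 nM in an assay on cells for inhibition of MAP kinase-interacting serine/threonine-protein kinase 1 (Homo sapiens), read by mobility shift assay, with stated times of 10 min and 60 min, in the presence of a further agent that is not named here; on this read-out lower numbers stand for stronger inhibition and higher numbers for weaker inhibition.
Compound 2 `CC(C)Oc1cc(-c2cncc(-c3cnn(C)c3)c2)ccc1C(N)=O` gives 400 nM in this assay.

Compound 2 stands at the lowest of the two numbers, with compound 1 at the higher number, a gap beyond the usual scatter. Compound 3 `CC(C)Oc1cc(-c2cccnc2)ccc1C(N)=O` has not been measured. It differs from compound 2 in one place: hydrogen in place of 1-methyl-1H-pyrazol-4-yl on an aromatic carbon. No two measured compounds differ in exactly this way, so the size of this step is not shown directly. The step of a 5.0-fold higher number from compound 2 to compound 3 (0.70 log units; beyond the scatter) is expected to move toward a higher number, beyond the scatter. Compound 3 is expected to give about 2000 nM, in the range 600 nM to 6000 nM.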

Compound 3, half-maximal inhibitory concentration: 880 nM
Compound 3: middle estimate off by 2.3-fold (0.36 log units), on the high side, within the range that was stated.
By their numbers in this assay, from the lowest: compound 2; then compounds 3 and 1 (each within the scatter of the next).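

The step of a 2.2-fold higher number from compound 2 to compound 3 (0.34 log units; beyond the scatter) in this assay is modest but beyond the scatter, so 1-methyl-1H-pyrazol-4-yl on this aromatic carbon lowers the number, yet inhibition remains with hydrogen there. The step of a 1.3-fold lower number from compound 1 to compound 3 (0.10 log units; within the scatter) lies within the scatter and separates isopropyl from piperidin-4-yl on the oxygen no further than repeat measurements would. Nothing given here accounts for either step. Going by these compounds, what stays open is whether a carboxylic acid or a methoxy group on this aromatic carbon would match 1-methyl-1H-pyrazol-4-yl, and whether that group gives a similar step alongside piperidin-4-yl on the oxygen.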